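Swapping a Small Ring for a Larger Aromatic Group

The compounds below may be only part of what the source reports. "The series", "measured", "known", "first", "only" and "open" are said of these compounds alone.

Of the compounds shown here, three sharing one core have been tested in an assay on isolated protein for binding affinity to histamine H2 receptor (Homo sapiens); a lower number here means a stronger inhibitor, a higher number a weaker inhibitor. Compound 1 `CCCCCC(=O)c1ccc(OCCCN2CCN(C(=O)CSCC)CC2)cc1` gives 22900 nM. Compound 2 `CCCCCC(=O)c1ccc(OCCCN2CCN(CCCC)CC2)cc1` gives 7590 nM; the step of a 3.0-fold lower number from compound 1 to compound 2 (0.48 log units; beyond the scatter) shows that a change on the ring nitrogen moved the number by a modest but real amount. Compound 3 `CCOC(=O)N1CCN(CCCOc2ccc(C(=O)C3CC3)cc2)CC1` gives 79400 nM, the highest of the three numbers and beyond the scatter from both of the others, so it is the weakest binder measured here.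

Compound 4 `CCOC(=O)N1CCN(CCCOc2ccc(C(=O)c3ccc(C(C)(C)C)cc3)cc2)CC1` differs from compound 3 in one place: 4-(tert-butyl)phenyl in place of cyclopropyl on a carbonyl carbon. Going by the values given here, no measured step touches this carbonyl carbon, so the only guide is indirect. Compounds 1 and 2 carry a longer chain at that position than compound 3 and show lower numbers, but they also differ at the ring nitrogen, so their values cannot be read as a clean step. The expectation is therefore a modest lowering, with wide uncertainty, giving a 2.6-fold lower number from compound 3 to compound 4 (0.42 log units; beyond the scatter). For compound 4 the expected value in this assay is 30000 nM, with a range from 8000 nM to 110000 nM.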

Compound 4, inhibition constant: 1550 nM
Estimate against measurement, compound 4: 19-fold (1.29 log units) above, outside the stated range (below it).
By their numbers in this assay, from the lowest: compound 4; then compound 2; then compound 1; then compound 3.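

In this assay, 4-(tert-butyl)phenyl in place of cyclopropyl on a carbonyl carbon gives a 51-fold lower number from compound 3 to compound 4 (1.71 log units; beyond the scatter). Going by these compounds alone, this is the first clean reading of this position, and it shows that the group on the carbonyl carbon can shift binding far more than the earlier change on the ring nitrogen did, a 3.0-fold lower number from compound 1 to compound 2 (0.48 log units; beyond the scatter). The change replaces a three-membered non-aromatic ring with a six-membered aromatic ring and brings in a group with more heavy atoms, but no available evidence explains why the number falls.

On these data alone, these changes come together, so their separate contributions remain open. A plain phenyl group would test what the tert-butyl adds, while a cyclohexyl group would test whether a large ring needs to be aromatic.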